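The source may hold more compounds than are shown below. What is called first, only, known or untested is meant among the compounds shown, and "the series" means these compounds.

Measured so far: compound 1 `CCNc1nc(/C=C/c2ccc(OC)c(OC)c2)cc(/C=C/c2ccc(OC)c(OC)c2)n1`, 46400 nM; compound 2 `COc1ccc(/C=C/c2cc(/C=C/c3ccc(OC)c(OC)c3)nc(NCCO)n2)cc1OC`, 6200 nM.

In a functional assay on HCT-116 cells (Homo sapiens) for inhibition, read by resazurin assay, with a stated time of 48 h (a higher number here means a weaker inhibitor, a lower number a stronger inhibitor), compound 2 stands lowest of the two numbers, its nearest neighbour being compound 1, which differs by a 7.5-fold lower number from compound 1 to compound 2 (0.87 log units; beyond the scatter). Compound 3 `CCCNc1nc(/C=C/c2ccc(OC)c(OC)c2)cc(/C=C/c2ccc(OC)c(OC)c2)n1` carries methyl in place of hydroxy on a saturated chain carbon, two bonds along the chain from a nitrogen on an aromatic ring. Among the compounds with values here, the only step that bears on this change is the one from compound 1 to compound 2, where a hydroxy entering gave a 7.5-fold lower number from compound 1 to compound 2 (0.87 log units; beyond the scatter); compound 3 loses that hydroxy again, gaining only a methyl, so the number is expected to move back up, by about a 4.8-fold higher number from compound 2 to compound 3 (0.68 log units; beyond the scatter). Compound 3 is therefore estimated at 30000 nM, in the range 8000 nM to 90000 nM.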

Compound 3, half-maximal inhibitory concentration: 28000 nM
For compound 3 the middle estimate is 1.1-fold (0.03 log units) above the measured one; measured number inside the range.
By their numbers in this assay, from the lowest: compound 2; then compounds 3 and 1 (each within the scatter of the next).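

In this assay, methyl in place of hydroxy at this position gives a 4.5-fold higher number from compound 2 to compound 3 (0.65 log units; beyond the scatter), so the lower number of compound 2 is not kept by propylamino, the chain of the same heavy-atom length without the hydroxy. Methyl in place of hydrogen on the chain gives a 1.7-fold lower number from compound 1 to compound 3 (0.22 log units; within the scatter), so among these compounds only compound 2, with its 2-hydroxyethyl group, stands apart. No evidence is available to explain this result. As far as these compounds go, whether an amine or a carboxylic acid in place of the hydroxy would match compound 2 remains open, as does the effect of a longer chain carrying the hydroxy.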